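Chloro for tert-butyl on a Weakly Cytotoxic Pair

This account rests on a few compounds, and the source may have more. Where it says the series, first, only, none or still open, it means among the compounds named here.

compound 1 `CC(C)(C)c1ccc(CN2C(=O)S/C(=C\c3ccc(N)cc3)C2=O)cc1` — 66000 nM
compound 2 `CC(C)(C)c1ccc(CN2C(=O)S/C(=C\c3cccc(N)c3)C2=O)cc1` — 165000 nM

In a functional assay on CCRF-CEM cells (Homo sapiens) for cytotoxicity, read by cell counting, with a stated time of 3 days (on this read-out lower numbers stand for stronger inhibition and higher numbers for weaker inhibition), compound 1 gives 66000 nM and compound 2 gives 165000 nM. Going by the values given here, compound 2 thus stands at the higher of the two numbers, and the only measured step, a 2.5-fold higher number from compound 1 to compound 2 (0.40 log units; beyond the scatter), concerns the position of the amino group on the aminophenyl ring. Compound 3 `Nc1cccc(/C=C2\SC(=O)N(Cc3ccc(Cl)cc3)C2=O)c1` differs from compound 2 as follows: chloro in place of tert-butyl on an aromatic carbon. Among the compounds with values here, no measured step touches this part of the shared core, so nothing in these data argues for a shift beyond the scatter in this assay. Compound 3 is therefore expected to give 165000 nM (range 55000 nM to 500000 nM), an expected step of no change at the digits printed from compound 2 to compound 3 (within the scatter).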

Compound 3, half-maximal inhibitory concentration: > 250000 nM
Compound 3: a limit, no number; the forecaster's own chance of this, stated with the estimate: 20%; middle value at least 1.5-fold (0.18 log units) from the limit.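

Compound 3 gives > 250000 nM in this assay, which is a limit of the assay and not a number. Going by these compounds alone, this is the first change to the group on the aromatic carbon of the benzyl end of the molecule, and chloro in place of tert-butyl gives an at least 1.5-fold higher number from compound 2 to compound 3 (0.18 log units; that floor lies within the scatter), so it brings no lower number, though its floor cannot be told from scatter. The true size of the step cannot be read, because the value is a limit: the limit of > 250000 nM in this assay, at which 1 of the 3 values shown sits.

From the compounds shown here alone, whether an amine, a carboxylic acid or a longer chain on this carbon would give a lower number stays open. So does whether chloro would act the same way alongside the 4-aminophenyl of compound 1.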